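Shortening an ethoxymethyl chain to methoxymethyl

The compounds below may be only part of what the source reports. "The series", "measured", "known", "first", "only" and "open" are said of these compounds alone.

compound 1 `CCOCc1c(C)coc1-c1ccc2c(c1OC)CCCC2(C)C` gives 22.9 uM
compound 2 `Cc1coc(-c2ccc3c(c2O)CCCC3)c1C(=O)O` gives 57 uM
compound 3 `CCc1cccc2c(O)c(-c3occ(C)c3C(=O)O)ccc12` gives 35.8 uM

In a functional assay on A549 cells (Homo sapiens) for cytotoxicity, read by sulforhodamine B assay, with a stated time of 3 days (a higher number here means that more compound is needed for the effect, a lower number that less compound is needed), compound 1 and compound 3 lie within the usual scatter of each other, while compound 2 shows a higher number than compound 1, beyond that scatter. The next compound to be tested is compound 4 `COCc1c(C)coc1-c1ccc2c(c1OC)CCCC2(C)C`, which departs from compound 1 at a single place, ethoxymethyl to methoxymethyl: hydrogen in place of methyl on a saturated chain carbon bound to an oxygen on a saturated carbon. In words, this puts hydrogen in place of methyl on a saturated chain carbon bound to an oxygen on a saturated carbon. Among the measured compounds shown here, no pair of measured compounds differs in one place only, so the data offer no direct precedent for this change. The expectation therefore starts from compound 1 at 22.9 uM in this assay and assumes no shift beyond the scatter, in either direction. The expected outcome is a small 1.1-fold higher number from compound 1 to compound 4 (0.04 log units; within the scatter), well inside that scatter. For compound 4 the estimated value is 25 uM, with an expected range from 12 uM to 50 uM.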

Compound 4, concentration for half-maximal effect: 19.4 uM
The estimate for compound 4 lay 1.3-fold (0.11 log units) above the measured number; the measured number falls inside the stated range.
By their numbers in this assay, from the lowest: compounds 4, 1, 3 and 2 (each within the scatter of the next, the first and the last beyond it).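

In this assay, among the compounds shown here, the only step between measured compounds that differ in one place is a 1.2-fold lower number from compound 1 to compound 4 (0.07 log units; within the scatter), which lies within the usual scatter. Hydrogen in place of methyl on a saturated chain carbon bound to an oxygen on a saturated carbon therefore leaves the number unresolved from that of the parent, so ethoxymethyl and methoxymethyl cannot be told apart here, something the earlier compounds, with no single-place pair among them, could not show. Nothing available explains this outcome.

This single step speaks only for ethoxy to methoxy on the core of compound 1. The compounds shown leave open what a longer chain such as propoxymethyl, or an amine in place of the ether oxygen, would do at this position.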